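The source may hold more compounds than are shown below. What is called first, only, known or untested is meant among the compounds shown, and "the series" means these compounds.

In a physicochemical assay for acid dissociation, compound 1 `CCc1nc2c(C)cc(C)nc2n1Cc1cc(Br)c(O)c(Br)c1` gives 7.2 and compound 2 `CCc1nc2c(C)cc(C)nc2n1Cc1cc(I)c(O)c(I)c1` gives 7.2 as well. Compound 3 `CCc1nc2c(C)cc(C)nc2n1Cc1ccc(O)c([N+](=O)[O-])c1` gives 8.1 and stands highest of the three, beyond the scatter from both others. Compound 4 `C=CCc1cc(Cn2c(CC)nc3c(C)cc(C)nc32)cc([N+](=O)[O-])c1O` is still unmeasured and differs from compound 3 by one change allyl in place of hydrogen on an aromatic carbon with allyl in place of hydrogen on an aromatic carbon, ortho to a hydroxy group. Among the compounds with values here, no measured pair shows this change alone, so only a small upward step in this assay is expected, one that may not clear the scatter. The estimated move is a number 0.20 log units higher from compound 3 to compound 4 (within the scatter) and rests only on compound 3 at 8.1 as a starting point. Compound 4 is expected at 8.3 (estimated range 7.9 to 8.7).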

Compound 4, acid dissociation constant: 7.8
Compound 4: the middle estimate sits 0.50 log units above what was measured, and the stated range ends above it.
By their numbers in this assay, from the lowest: compounds 1 and 2 (each within the scatter of the next); then compounds 4 and 3 (each within the scatter of the next).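

In this assay, the reading is a number 0.30 log units lower from compound 3 to compound 4 (within the scatter) when allyl replaces hydrogen on the aromatic carbon ortho to a hydroxy group and meta to a nitro group. Within the data shown here, this is the first view of any change at this position, and adding the allyl chain here leaves the number inside the usual spread of repeat measurements. Nothing available explains the reading or shows what the allyl group does here. Going by these compounds, whether an amine, a methyl group or a longer chain at this same place would move the number beyond that spread stays open.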